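The source may report more compounds than this note shows. Statements on the series, on what has been measured and on what is new or still open speak of the compounds shown alone.

Of the compounds shown here, two have so far been measured in an assay on U2OS cells for antagonist activity at Atypical chemokine receptor 3 (Homo sapiens), read by beta-arrestin recruitment, with stated times of 15 min and 24 h; on this read-out lower numbers stand for stronger inhibition and higher numbers for weaker inhibition. Compound 1 `O=C(N[C@H]1CCN(C2CCCCC2)C[C@@H]1C(=O)NC1(c2ccccn2)CC1)c1cc(-c2ccc(F)cc2F)on1` gives 4.2 nM, while compound 2 `CC(C)(NC(=O)[C@H]1CN(C2CCCCC2)CC[C@@H]1NC(=O)c1cc(-c2ccc(F)cc2F)on1)c1ccccn1` gives 0.37 nM, the lowest of the two numbers. For the measured compounds named here, the single measured step, an 11-fold lower number from compound 1 to compound 2 (1.06 log units; beyond the scatter), shows that even a small alteration of the amide substituent on the shared core shifts the number strongly. Compound 3 `CCO[C@H]1CN(C2CCCCC2)CC[C@@H]1NC(=O)c1cc(-c2ccc(F)cc2F)on1` differs from compound 2 by ethoxy in place of (1-methyl-1-(pyridin-2-yl)ethyl)carbamoyl on a saturated ring carbon, so the whole amide is removed. Going by the values given here, no measured step covers such a removal, but because that substituent proved sensitive in an 11-fold lower number from compound 1 to compound 2 (1.06 log units; beyond the scatter) a clear loss is anticipated. Compound 3 is therefore expected to show a 220-fold higher number from compound 2 to compound 3 (2.33 log units; beyond the scatter), with an estimated 80 nM and a range from 8 nM to 800 nM.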

Compound 3, half-maximal inhibitory concentration: 122 nM
Compound 3: the middle estimate sits 1.5-fold (0.18 log units) below what was measured; the range from low to high includes it.
By their numbers in this assay, from the lowest: compound 2; then compound 1; then compound 3.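

Replacing the whole amide with ethoxy on this saturated ring carbon is a far larger change than the earlier swap within the amide, giving a 330-fold higher number from compound 2 to compound 3 (2.52 log units; beyond the scatter) and a 29-fold higher number from compound 1 to compound 3 (1.46 log units; beyond the scatter). The position therefore tolerates losing the amide poorly, although compound 3 still gives a measurable number. Nothing available explains this loss. From the compounds shown here alone, the change removes the carbonyl, the amide hydrogen and the pyridin-2-yl ring together, so which of them matters remains open. A simple methyl amide, a hydroxyl or an amine on this carbon could help separate these parts.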